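A group swap with no measured starting point

The compounds below may be only part of what the source reports. "The series", "measured", "known", "first", "only" and "open" are said of these compounds alone.

Within the data shown here, in an ADME assay on J774.A1 cells (Mus musculus) for cytotoxicity, read by MTT assay, with a stated time of 48 h (a higher number here means that more compound is tolerated, a lower number that less compound is tolerated), compound 2 (`Cc1ccc(Cn2cc(COC(=O)c3c(C)nc4ccccc4c3-c3ccccc3)nn2)cc1`) gives 41000 nM as the only number so far. Compound 1 (`Cc1nc2ccccc2c(-c2ccccc2)c1C(=O)OCc1cn(-c2ccc(C(C)C)cc2)nn1`) stands at "not determined" (no result reported) in the same test. Compound 3 (`Cc1nc2ccc(Cl)cc2c(-c2ccccc2)c1C(=O)OCc1cn(-c2ccc(C(C)C)cc2)nn1`) has no single number either, its entry reading "not determined" (no result reported) so far, which leaves the step below without a measured start. Compound 4 (`Cc1nc2ccc(Cl)cc2c(-c2ccccc2)c1C(=O)OCc1cn(Cc2ccc([N+](=O)[O-])cc2)nn1`) carries 4-nitrobenzyl in place of 4-isopropylphenyl on an aromatic nitrogen. Among the measured compounds shown here, no measured step exists to guide this change, so the step expected in this assay is none beyond the scatter, and compound 2 at 41000 nM serves as the only anchor. For compound 4 the estimated value is 40000 nM with an expected range of 15000 nM to 100000 nM in this measurement.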

Compound 4, half-maximal cytotoxic concentration: 75000 nM
Beside the measured number, compound 4's estimate is 1.9-fold (0.27 log units) below it, within the range that was stated.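

In this assay, among these compounds, compound 3 stands at "not determined" (no result reported), so compound 4 at 75000 nM gives no step from it. No evidence shown bears on this result. Going by these compounds, whether swapping 4-isopropylphenyl for 4-nitrobenzyl changes how much compound is tolerated remains open.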